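Replacing Methyl with 4-Bromophenyl on a Saturated Chain Carbon

The source may report more compounds than this note shows. Statements on the series, on what has been measured and on what is new or still open speak of the compounds shown alone.

In a functional assay on DU-145 cells (Homo sapiens) for cytotoxicity, read by trypan blue exclusion, with a stated time of 96 h (a higher number here means a weaker inhibitor, a lower number a stronger inhibitor), compound 1 (`COc1cc(OC)c(/C=C/S(=O)(=O)Nc2ccc(OC)c(OP(=O)(O)O)c2)c(OC)c1`) gives 40 nM and compound 2 (`COc1cc(OC)c(/C=C/S(=O)(=O)Nc2ccc(OC)c(NC(C)C(=O)O)c2)c(OC)c1`) gives 40 nM as well, which puts compound 2 level with compound 1. Compound 3 (`COc1cc(OC)c(/C=C/S(=O)(=O)Nc2ccc(OC)c(NC(C(=O)O)c3ccc(Br)cc3)c2)c(OC)c1`) differs from compound 2 at one place (4-bromophenyl in place of methyl on a saturated chain carbon bound to a carbonyl carbon and a nitrogen on an aromatic ring), with 4-bromophenyl in place of methyl on a saturated chain carbon bound to a carbonyl carbon and a nitrogen on an aromatic ring. For the measured compounds named here, the one measured step (no change at the digits printed from compound 1 to compound 2 (within the scatter)) changed a group on an aromatic carbon and left this chain carbon out of play, so it offers only weak guidance. Going by the values given here, no measured pair tests the new group. The expected step (a 1.5-fold higher number from compound 2 to compound 3 (0.18 log units; within the scatter)) in this assay is therefore small, leaning towards weaker inhibition and perhaps staying within the scatter. For compound 3 the estimated value is 60 nM (expected range 20 nM to 200 nM).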

Compound 3, half-maximal inhibitory concentration: 250 nM
Beside the measured number, compound 3's estimate is 4.2-fold (0.62 log units) below it, outside the stated range (above it).
By their numbers in this assay, from the lowest: compounds 1 and 2 (each within the scatter of the next); then compound 3.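

In this assay, the saturated chain carbon bound to a carbonyl carbon and a nitrogen on an aromatic ring proves sensitive to what it carries: 4-bromophenyl in place of methyl gives a 6.3-fold higher number from compound 2 to compound 3 (0.80 log units; beyond the scatter), a modest weakening. The earlier step on the aromatic carbon stayed within the scatter, but the larger group of compound 3 in that place gives a 6.3-fold higher number from compound 1 to compound 3 (0.80 log units; beyond the scatter), so that site does not treat every group alike. Nothing shown gives a reason for this weakening.

Going by these compounds, it remains open whether the weakening follows the ring or the bromine, which a plain phenyl ring on the same carbon would help to separate. On these data alone, it is also open whether a longer chain there, such as ethyl or propyl, would read like methyl or like 4-bromophenyl.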